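A few compounds are considered here, and "the series" means these few. Any claim that something is new, unique, unknown or untested is made for them only; others in the source may bear on it.

Working notes on the series. Compound 1 `O=C(O)Cc1sc(C(c2ccccc2)c2ccccc2)nc1-c1ccc(F)cc1` gives 80% in an in vitro functional assay on HEK285-7 cells for antagonist activity at prostaglandin D2 receptor 2 (Homo sapiens), read by BRET and beta-arrestin recruitment; on this read-out lower numbers stand for smaller maximal responses and higher numbers for larger maximal responses. Compound 2 `O=C(O)Cc1sc(C(c2ccccc2)c2ccccc2)nc1-c1ccc(F)c(F)c1` gives 80%, and compound 3 `O=C(O)Cc1sc(C(c2ccccc2)c2ccccc2)nc1-c1ccccc1` gives 80%. Compound 3 thus sits level with compounds 1 and 2: the step of no change at the digits printed from compound 1 to compound 3 (within the scatter) and the step of no change at the digits printed from compound 2 to compound 3 (within the scatter) both stay within the scatter, as does no change at the digits printed from compound 1 to compound 2 (within the scatter). Compound 4 `O=C(O)Cc1sc(C(c2ccccc2)c2ccccc2)nc1-c1ccc(C(F)(F)F)cc1` differs from compound 3 by trifluoromethyl in place of hydrogen on an aromatic carbon. Among the measured compounds shown here, the measured exchanges of fluoro and hydrogen on an aromatic carbon are the steps that bear on this change, and each was flat. For the measured compounds named here, no measured step involves a trifluoromethyl group. The expected step in this assay is therefore no change at the digits printed from compound 3 to compound 4 (within the scatter), nothing beyond the scatter. Compound 4 is estimated at 80%, between 70% and 90%.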

Compound 4, largest response reached (reported as efficacy), in percent of the reference or control that the assay uses: 80%
Compound 4: the middle estimate sits on the measured number at the digits printed, within the range that was stated.
By their numbers in this assay, from the lowest: compounds 1, 2, 3 and 4 (each within the scatter of the next).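

In this assay this position on the six-membered aromatic ring takes trifluoromethyl, with its 4 heavy atoms, and the read-out stays flat, with no change at the digits printed from compound 3 to compound 4 (within the scatter) and no change at the digits printed from compound 1 to compound 4 (within the scatter) and no change at the digits printed from compound 2 to compound 4 (within the scatter). The earlier compounds shown here carried only hydrogen and fluoro on this ring, so the flat result now extends to a substituent with more heavy atoms. Nothing available gives a reason for this flat result.

On these data alone, whether an amine or a methoxy group at this position would also leave the maximal response level remains open.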